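Phenyl for pyridin-3-yl on a pyrazolopyrimidinone-type core

This account rests on a few compounds, and the source may have more. Where it says the series, first, only, none or still open, it means among the compounds named here.

Measured compounds:
Compound 1, `Cc1nn(C)c2c(O)nc(-c3cccnc3)nc12`: 3090 nM
Compound 2, `CCn1c(=O)n(C)c(=O)c2[nH]c(-c3ccccc3)nc21`: 3 nM

In an assay on membranes from brain for binding affinity to adenosine receptor A1 (Rattus norvegicus), read by radioligand binding (a higher number here means a weaker inhibitor, a lower number a stronger inhibitor), compound 1 gives 3090 nM, the highest of the two numbers recorded. For the measured compounds named here, compound 2, built on a different core, gives 3 nM in this assay, a far lower number; the two values are separated by a gap well beyond the scatter, but no single structural step links these two compounds, so their values show only that two different cores sit very far apart.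

Compound 3, `Cc1nn(C)c2c(O)nc(-c3ccccc3)nc12`, has not been measured. It differs from compound 1 in one place: phenyl in place of pyridin-3-yl on an aromatic carbon. Going by the values given here, no pair of measured compounds isolates this exchange, so the size of the step cannot be read from the data. The change removes one hydrogen-bond acceptor and otherwise keeps the ring the same size. A modest shift toward a lower number is expected, one that may not exceed the scatter, giving an estimated step of a 2.1-fold lower number from compound 1 to compound 3 (0.31 log units; beyond the scatter) for compound 3. Compound 3 is thus expected to give about 1500 nM in this assay, within a range from 300 nM to 6000 nM.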

Compound 3, half-maximal inhibitory concentration: 1020 nM
Beside the measured number, compound 3's estimate is 1.5-fold (0.17 log units) above it; the measured number falls inside the stated range.
By their numbers in this assay, from the lowest: compound 2; then compound 3; then compound 1.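

In this assay, phenyl in place of pyridin-3-yl on the aromatic carbon between two ring nitrogen atoms gives a 3.0-fold lower number from compound 1 to compound 3 (0.48 log units; beyond the scatter). For the compounds shown here, this is the first step that can be read on this core, and it shows that this position responds to the exchange, modestly but beyond the scatter. A ring of carbon only is therefore tolerated here, and the ring nitrogen of pyridin-3-yl is not required to reach the lower number, though nothing available explains the shift.

As far as these compounds go, whether a pyridin-4-yl ring, or a phenyl ring carrying a methoxy group or an amine, would move the number further on this core remains open. From the compounds shown here alone, it is also open whether the same exchange would produce a step of similar size on the core of compound 2.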